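The source may hold more compounds than are shown below. What is called first, only, known or untested is meant among the compounds shown, and "the series" means these compounds.

Measured compounds:
compound 1, `Cc1ccccc1COc1ccc(N2CCC[C@H]2CC(=O)O)cc1` — 190 nM in a functional assay on cells for agonist activity at Free fatty acid receptor 1 (Homo sapiens), read by FLIPR and calcium flux, with a stated time of 100 s; on this read-out lower numbers stand for an effect already at smaller amounts and higher numbers for an effect only at larger amounts of compound
compound 2, `O=C(O)C[C@@H]1CCCN1c1ccc(Oc2ccccc2F)cc1` — 150 nM in this assay
compound 3, `Cc1cccc(Oc2ccc(N3CCC[C@H]3CC(=O)O)cc2)c1` — 260 nM in this assay

Among these three numbers, compound 2 gives the lowest, but the steps of a 1.3-fold lower number from compound 1 to compound 2 (0.10 log units; within the scatter) and a 1.7-fold higher number from compound 2 to compound 3 (0.24 log units; within the scatter) both lie within the scatter, so compound 2 cannot be called more potent than either of the other two. The three compounds share the same core and differ only in the group carried on the ether oxygen; across those three variations the numbers barely move, as the step of a 1.4-fold higher number from compound 1 to compound 3 (0.14 log units; within the scatter) also shows.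

Compound 4, `CC(C)(C)c1ccccc1Oc1ccc(N2CCC[C@H]2CC(=O)O)cc1`, is the next member of this set and has not yet been measured in this assay. Relative to compound 2 the change is tert-butyl in place of fluoro on an aromatic carbon. Among the compounds with values here, the steps that bear on it are the three ether-group exchanges, all of which stayed within the scatter. Within the data shown here, the group entering here is the bulkiest seen so far, and no measured step tests such a group in this position, so the expectation carries some uncertainty. On the evidence available, the expected step from compound 2 to compound 4 in this assay is a 1.3-fold higher number from compound 2 to compound 4 (0.12 log units; within the scatter), that is, nothing beyond the scatter. Compound 4 is therefore estimated at 200 nM, with a plausible range from 70 nM to 600 nM.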

Compound 4, half-maximal effective concentration: 6500 nM
Estimate against measurement, compound 4: 33-fold (1.51 log units) below, outside the stated range (above it).
By their numbers in this assay, from the lowest: compounds 2, 1 and 3 (each within the scatter of the next); then compound 4.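

In this assay, within the data shown here, the exchange of fluoro for tert-butyl on an aromatic carbon, ortho to a large group, gives a 43-fold higher number from compound 2 to compound 4 (1.64 log units; beyond the scatter) and is the only step in this set that lies beyond the scatter. The earlier compounds shown here replaced the entire group on the ether oxygen without any step leaving the scatter, and so gave no sign that the read-out could respond strongly to a change in this part of the molecule; this single exchange, from one heavy atom to four, shows that it can. The data shown offer no measured finding that accounts for the size of this step.

What remains open is how the number changes between these two extremes, since no compound shown carries a chloro, an ethyl or an isopropyl group on this same aromatic carbon. From the compounds shown here alone, it is also open whether a methoxy group, or an amine such as dimethylamino, would follow tert-butyl here or stay close to compound 2, and whether tert-butyl would give a similar result on another carbon of the ring.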